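Series notes: benzamide linker extended to a cinnamamide

This account rests on a few compounds, and the source may have more. Where it says the series, first, only, none or still open, it means among the compounds named here.

Measured so far in a functional assay on NCI-H460 cells (Homo sapiens) for antiproliferative activity, read by CCK-8 assay, with a stated time of 72 h, tested at 2 uM; on this read-out lower numbers stand for a weaker effect and higher numbers for a stronger effect at the one concentration tested:
compound 1 `Cc1ccc(Nc2nc(Cl)nc3c2ncn3Cc2ccc(C(=O)Nc3ccccc3N)cc2)cc1` gives 67.3%
compound 2 `Nc1ccccc1NC(=O)c1ccc(Cn2cnc3c(Nc4ccccc4)nc(Cl)nc32)cc1` gives 42.7%

Compound 1 stands highest of the two numbers recorded; the nearest is compound 2, reached by a number 24.6 percentage points lower from compound 1 to compound 2 (beyond the scatter), a change of hydrogen in place of methyl on an aromatic carbon.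

The unmeasured compound 3 `Cc1ccc(Nc2nc(Cl)nc3c2ncn3Cc2ccc(/C=C/C(=O)Nc3ccccc3N)cc2)cc1` keeps the core of compound 1 and differs as 2-((2-aminophenyl)carbamoyl)ethenyl in place of (2-aminophenyl)carbamoyl on an aromatic carbon. The change is 2-((2-aminophenyl)carbamoyl)ethenyl in place of (2-aminophenyl)carbamoyl on an aromatic carbon, para to a large group.

For the measured compounds named here, no measured step bears on this change: the single step known alters the methyl on the anilino ring, not the carbamoyl portion. The expectation for compound 3 in this assay therefore rests on compound 1 alone, with no direction indicated beyond the scatter. The step is estimated as a number 3.3 percentage points lower from compound 1 to compound 3 (within the scatter), and the range is set wide to reflect the absence of a comparable step. Compound 3 is estimated at 64%, between 42% and 84%.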

Compound 3, a percentage reported as inhibition, at one concentration (the size of the read-out at that concentration, not a potency): 31.3%
The estimate for compound 3 lay 32.7 percentage points above the measured number, outside the stated range (below it).
By their numbers in this assay, from the lowest: compound 3; then compound 2; then compound 1.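

In this assay, this position on an aromatic carbon, para to a large group, does not tolerate every extension: putting 2-((2-aminophenyl)carbamoyl)ethenyl in place of (2-aminophenyl)carbamoyl gives a number 36 percentage points lower from compound 1 to compound 3 (beyond the scatter). For the compounds shown here, the earlier compounds differed only by a methyl on an aromatic carbon, so this is the first sign that the carbamoyl-bearing end of the series also affects the read-out at the one concentration tested, with the shared core and the methyl held constant. Nothing available explains why this change lowers the number.

The compounds shown leave open whether the drop belongs to the ethenyl double bond itself or would also appear with a saturated ethylene chain, or with a longer chain, carrying the same 2-aminophenyl amide. They also leave open whether a hydroxamic acid in place of the 2-aminophenyl amide would behave differently on the ethenyl linker, and whether hydrogen in place of methyl would lower the number on that linker as it does on the shorter one.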